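Replacing a Methyl Ether with an Oxolanyl Ether

This account rests on a few compounds, and the source may have more. Where it says the series, first, only, none or still open, it means among the compounds named here.

Three compounds were measured in a functional assay on PC-3 cells (Homo sapiens) for antiproliferative activity, read by MTT assay, with a stated time of 72 h; on this read-out lower numbers stand for stronger inhibition and higher numbers for weaker inhibition:

compound 1 `CC(C)=CC(=O)Nc1cc2c(N3CCc4ccccc43)ncnc2cc1O[C@@H]1CCOC1`: 4620 nM
compound 2 `COc1cc2ncnc(N3CCCc4ccccc43)c2cc1NC(=O)C=C(C)C`: 6130 nM
compound 3 `CC/C=C/C(=O)Nc1cc2c(N3CCCc4ccccc43)ncnc2cc1OC`: 6310 nM

Compound 2 stands second highest of these three numbers; its nearest neighbour is compound 3, reached by the step of a 1.0-fold higher number from compound 2 to compound 3 (0.01 log units; within the scatter), and its furthest is compound 1, whose number is also within the scatter of compound 2. Compound 4 `CC(C)=CC(=O)Nc1cc2c(N3CCCc4ccccc43)ncnc2cc1O[C@@H]1CCOC1` differs from compound 2 by oxolan-3-yl in place of methyl on an oxygen on an aromatic ring. Within the data shown here, no measured step makes this same change; the only step measured alters the amide side chain and lies within the scatter. Compound 1 carries the same oxolanyl ether and the same amide side chain and gives 4620 nM, close to compound 2. Compound 4 is therefore expected to show no step beyond the scatter, a 1.2-fold lower number from compound 2 to compound 4 (0.09 log units; within the scatter). Compound 4 is estimated at 5000 nM, with a range from 2200 nM to 11500 nM.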

Compound 4, half-maximal inhibitory concentration: 9020 nM
Compound 4: middle estimate off by 1.8-fold (0.26 log units), on the low side; low and high end bracket the measured number.
By their numbers in this assay, from the lowest: compounds 1, 2, 3 and 4 (each within the scatter of the next).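

In this assay, among these compounds, oxolan-3-yl in place of methyl on an oxygen on an aromatic ring gives a 1.5-fold higher number from compound 2 to compound 4 (0.17 log units; within the scatter) and so offers the first direct reading of this change, which leaves the number inside the scatter. With the oxolanyl ether held fixed, 1,2,3,4-tetrahydroquinolin-1-yl in place of 2,3-dihydro-1H-indol-1-yl on an aromatic carbon gives a 2.0-fold higher number from compound 1 to compound 4 (0.29 log units; within the scatter) and also stays inside it. Nothing available bears on why these numbers fall where they do. As far as these compounds go, it remains open whether an ether carrying an amine, such as dimethylaminoethoxy, on that same oxygen would produce a step beyond the scatter.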